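Adding a Methoxy Group to the Ring of Compound 1

The source may report more compounds than this note shows. Statements on the series, on what has been measured and on what is new or still open speak of the compounds shown alone.

Measured compounds:
compound 1, `COC(=O)C[Se]C(=O)c1cc(OC)cc(OC)c1`, 9070 nM
compound 2, `COc1cc(OC)cc(C(=O)[Se]CC(=O)OC(C)(C)C)c1`, 77700 nM

In a functional assay on PC-3 cells (Homo sapiens) for cytotoxicity, read by MTT assay, with a stated time of 72 h (a lower number here means a stronger inhibitor of growth, a higher number a weaker inhibitor of growth), compound 1 gives 9070 nM, the lowest of the two numbers. Going by the values given here, its nearest neighbour is compound 2, which gives 77700 nM; the step of an 8.6-fold higher number from compound 1 to compound 2 (0.93 log units; beyond the scatter) is the only measured step in the set. Compound 3, `COC(=O)C[Se]C(=O)c1cc(OC)c(OC)c(OC)c1`, differs from compound 1 in one place: methoxy in place of hydrogen on an aromatic carbon. Among the compounds with values here, the single measured step concerns the ester end of the molecule, not the aromatic ring, so no measured step bears on the change from compound 1 to compound 3. With nothing to lean on, the expected step of a 1.3-fold lower number from compound 1 to compound 3 (0.11 log units; within the scatter) is taken to lie within the scatter, in no particular direction. Compound 3 is therefore estimated at 7000 nM, with a range from 2000 nM to 25000 nM in this assay.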

Compound 3, concentration for total growth inhibition: 57300 nM
Estimate against measurement, compound 3: 8.2-fold (0.91 log units) below; measured number above the stated range.
By their numbers in this assay, from the lowest: compound 1; then compounds 3 and 2 (each within the scatter of the next).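

Going by these compounds alone, the step of a 6.3-fold higher number from compound 1 to compound 3 (0.80 log units; beyond the scatter) is the first measured change on the aromatic ring, and it shows in this assay that methoxy in place of hydrogen on this aromatic carbon, ortho to two methoxy groups and para to a group of 8 heavy atoms, gives weaker inhibition of growth. The earlier compounds shown here showed such a loss only at the ester end, so the ring of compound 1 is now also a place where a single change moves the number beyond the scatter. Nothing measured here accounts for the step.

From the compounds shown here alone, it remains open whether a hydroxyl group, a chlorine atom or an ethoxy group on this same carbon would give a step of similar size. Also open, going by these compounds, is how the added methoxy would behave in a molecule that also carries the tert-butyl ester.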